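Replacing a Hydroxyphenyl by a Chlorophenyl in a Hydrazone Series

The source may hold more compounds than are shown below. What is called first, only, known or untested is meant among the compounds shown, and "the series" means these compounds.

Compound 1 `O=C(COc1cccc2ccccc12)N/N=C/c1ccccc1O` is the point of departure. In an ADME assay on HEL cells (Homo sapiens) for cytotoxicity (on this read-out higher numbers stand for lower toxicity in this test and lower numbers for higher toxicity in this test), compound 1 gives 20 ug/mL. Among the measured compounds shown here, its one measured neighbour, compound 2 `O=C(COc1cccc2ccccc12)N/N=C/c1ccccc1[N+](=O)[O-]`, gives 20 ug/mL in this assay, and the step of no change at the digits printed from compound 1 to compound 2 (within the scatter) shows that the two sit level at the digits printed; compound 1 stands within the scatter of compound 2, and nothing else has been measured.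

Compound 3 `O=C(COc1cccc2ccccc12)N/N=C/c1cccc(Cl)c1` has yet to be tested in this assay. It differs from compound 1 by 3-chlorophenyl in place of 2-hydroxyphenyl on a carbon with a double bond to nitrogen. For the measured compounds named here, the only measured step that bears on this, from compound 1 to compound 2, also exchanged the group on the aromatic ring attached to the carbon with a double bond to nitrogen, and it produced no change at the digits printed from compound 1 to compound 2 (within the scatter). Going by the values given here, that is a loose analogy, since a hydroxy-to-nitro exchange is not a hydroxy-to-chlorine exchange at another place on the ring, but it is the only guide. The expected step of no change at the digits printed from compound 1 to compound 3 (within the scatter) is therefore none beyond the scatter. Compound 3 is estimated at 20 ug/mL, with a range from 10 ug/mL to 40 ug/mL.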

Compound 3, minimum cytotoxic concentration: 100 ug/mL
Compound 3: middle estimate off by 5.0-fold (0.70 log units), on the low side; measured number outside the range, above it.
By their numbers in this assay, from the lowest: compounds 1 and 2 (each within the scatter of the next); then compound 3.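

Compound 2 gave the impression that the aromatic group on the carbon with a double bond to nitrogen could be altered without effect, with no change at the digits printed from compound 1 to compound 2 (within the scatter) in this assay. Compound 3 shows that this place is not indifferent to every change, since 3-chlorophenyl in place of 2-hydroxyphenyl gives a 5.0-fold higher number from compound 1 to compound 3 (0.70 log units; beyond the scatter), a modest move towards lower toxicity in this test while the rest of the molecule stays the same. No measurement here accounts for this difference between the two exchanges.

The compounds shown leave open whether the step belongs to the chlorine itself or to its different place on the ring, since 3-chlorophenyl differs from 2-hydroxyphenyl in both the atom carried and the number in its name, and a single pair cannot separate the two. Also open, going by these compounds, is whether this assay would move further with an amine or a carboxylic acid on that aromatic ring, or with a longer chain in place of the ring.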